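A few compounds are considered here, and "the series" means these few. Any claim that something is new, unique, unknown or untested is made for them only; others in the source may bear on it.

Compounds measured in a functional assay on ACHN cells (Homo sapiens) for inhibition, read by sulforhodamine B assay, with a stated time of 48 h, tested at 10 uM; on this read-out lower numbers stand for less inhibition and higher numbers for more inhibition at the one concentration tested (going by the name of the read-out):
compound 1, `COc1ccc(-c2cn3ccnc3c(-c3ccc4ncn(C5CCCCC5)c4c3)n2)cc1`: 61%
compound 2, `c1ccc2c(-c3cn4ccnc4c(-c4ccc5ncn(C6CCCCC6)c5c4)n3)cccc2c1`: 6.49%

Compound 2 stands lowest of the two numbers, far under compound 1. Compound 3, `Fc1ccc(-c2cn3ccnc3c(-c3ccc4ncn(C5CCCCC5)c4c3)n2)cc1`, is not yet measured. The change is 4-fluorophenyl in place of naphthalen-1-yl on an aromatic carbon. For the measured compounds named here, the one measured step that bears on it is a number 54.5 percentage points lower from compound 1 to compound 2 (beyond the scatter), a large fall when the two-ring group replaced a one-ring group. Compound 3 returns to a one-ring group, so a large rise in this assay is expected, though the fluorine differs from the methoxy of compound 1. Compound 3 is estimated at 45%, within 15% to 72%, a step of a number 38.5 percentage points higher from compound 2 to compound 3 (beyond the scatter).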

Compound 3, a percentage reported as inhibition, at one concentration (the size of the read-out at that concentration, not a potency): 9.02%
Beside the measured number, compound 3's estimate is 36 percentage points above it; the whole stated range lies above it.
By their numbers in this assay, from the lowest: compounds 2 and 3 (each within the scatter of the next); then compound 1.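

In this assay, 4-fluorophenyl in place of naphthalen-1-yl gives a number 2.5 percentage points higher from compound 2 to compound 3 (within the scatter), so at this position a one-ring group does not by itself restore the number seen for compound 1. Fluoro in place of methoxy gives a number 52 percentage points lower from compound 1 to compound 3 (beyond the scatter), which ties the high number of compound 1 to its methoxy group rather than to the single ring alone. No measurement at hand explains this difference. On these data alone, it remains open whether the effect is specific to methoxy or would also appear with a hydroxyl, an ethoxy or a dimethylamino group in the same place.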